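Cytotoxicity notes: replacing the amino group of compound 2

The source may report more compounds than this note shows. Statements on the series, on what has been measured and on what is new or still open speak of the compounds shown alone.

Of the compounds shown here, three have been measured in an ADME assay on L6 cells (Rattus norvegicus) for cytotoxicity, read by resazurin assay, with a stated time of 72 h; a higher number here means a weaker inhibitor, a lower number a stronger inhibitor. Compound 1 `CN(C)C12CC(N)C(C(c3ccccc3)C1)C(c1ccccc1)C2` gives 40900 nM; compound 2 `NC1CC2(N3CCCC3)CC(c3ccccc3)C1C(c1ccccc1)C2` gives 38100 nM; compound 3 `CN1CCN(CC(=O)N2CCC3(N(C)C)CC(c4ccccc4)C2C(c2ccccc2)C3)CC1`, carrying a (((4-methylpiperazin-1-yl)methyl)carbonyl) group on a ring nitrogen, gives 195000 nM. Compound 2 holds the lowest of the three numbers, but its gap to compound 1 lies within the scatter; only compound 3 stands apart from it. Going by the values given here, the single one-place step measured so far, a 1.1-fold lower number from compound 1 to compound 2 (0.03 log units; within the scatter), carries no signal.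

Compound 4 `CN1CCN(CC(=O)OC2CC3(N4CCCC4)CC(c4ccccc4)C2C(c2ccccc2)C3)CC1` is not yet measured. It differs from compound 2 by (((4-methylpiperazin-1-yl)methyl)carbonyl)oxy in place of amino on a saturated ring carbon. Among the compounds with values here, no measured step covers this change; the step from compound 1 to compound 2 concerns a different group and is within the scatter. Within the data shown here, the only guide is that compound 3, the one compound carrying the 4-methylpiperazin-1-yl group, sits at 195000 nM, well above compound 2 at 38100 nM, though the two differ in more than one place and their gap cannot be assigned to that group alone. A move toward higher numbers is therefore expected for compound 4, of about a 2.9-fold higher number from compound 2 to compound 4 (0.46 log units; beyond the scatter). The estimate for compound 4 is 110000 nM, in the range 45000 nM to 260000 nM.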

Compound 4, half-maximal inhibitory concentration: 24600 nM
Estimate against measurement, compound 4: 4.5-fold (0.65 log units) above; measured number outside the range, below it.
By their numbers in this assay, from the lowest: compounds 4, 2 and 1 (each within the scatter of the next); then compound 3.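

In this assay, the saturated ring carbon that carries the amino group in compound 2 accepts (((4-methylpiperazin-1-yl)methyl)carbonyl)oxy, with 11 heavy atoms entering where 1 leaves, and the outcome is a 1.5-fold lower number from compound 2 to compound 4 (0.19 log units; within the scatter) for this exchange. Going by these compounds alone, this is the first one-place step read at this position, and it shows that neither the added ring nor the loss of the amino group's hydrogen-bond donor comes with a readable change in the number, although a group of this size and a single heavy atom are being exchanged. No evidence on the reason for this outcome accompanies the result.

Which part of the entering group matters, if any, stays open: a hydroxyl, a simple acetyl ester or an amide on this carbon would separate the contribution of the linkage from that of the 4-methylpiperazin-1-yl ring. Also open, on these data alone, are whether the same exchange reads alike with dimethylamino in place of pyrrolidin-1-yl on the shared core, and how a longer chain within the entering group would read.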